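From ethyl to bromo on the shared core

This account rests on a few compounds, and the source may have more. Where it says the series, first, only, none or still open, it means among the compounds named here.

Compound 1 `CCc1cc2nc(O)c(O)nc2c([N+](=O)[O-])c1Br`: 11 mg/kg
Compound 2 `CCc1cc2nc(O)c(O)nc2c([N+](=O)[O-])c1Cl`: 4.5 mg/kg

Among the compounds with values here, in a functional assay on the whole organism with Mus musculus as the target, in the maximal electroshock model (on this read-out higher numbers stand for an effect only at larger amounts of compound and lower numbers for an effect already at smaller amounts), compound 1 gives 11 mg/kg, the higher of the two numbers so far. Compound 3 `O=[N+]([O-])c1c(Br)c(Br)cc2nc(O)c(O)nc12`, not yet measured, departs from it in one place: bromo in place of ethyl on an aromatic carbon. Within the data shown here, the only measured step, a 2.4-fold lower number from compound 1 to compound 2 (0.39 log units; beyond the scatter), exchanges chloro for bromo and leaves the ethyl in place, so it bears only indirectly and gives no direction. A shift no larger than that one is expected, most likely within the scatter. The estimated change is a 1.2-fold lower number from compound 1 to compound 3 (0.09 log units; within the scatter). For compound 3 the expected value is 9 mg/kg, within an estimated range of 3 mg/kg to 27 mg/kg.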

Compound 3, dose for half-maximal effect: 7.3 mg/kg
Compound 3: middle estimate off by 1.2-fold (0.09 log units), on the high side; low and high end bracket the measured number.
By their numbers in this assay, from the lowest: compounds 2, 3 and 1 (each within the scatter of the next, the first and the last beyond it).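

The exchange of ethyl for bromo on this aromatic carbon comes with a 1.5-fold lower number from compound 1 to compound 3 (0.18 log units; within the scatter), so in this assay the two groups cannot be told apart at this position. Within the data shown here, the earlier step concerned only chloro in place of bromo with the ethyl left in place, so this is the first direct reading of the ethyl position itself. Nothing available on these compounds offers an explanation for this result.

From the compounds shown here alone, whether the position would accept a longer chain such as propyl, an amine or a carboxylic acid remains open. So does the outcome with chloro here.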